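Swapping a Nitrile-Bearing Group for an Aryl Formamidine

The compounds below may be only part of what the source reports. "The series", "measured", "known", "first", "only" and "open" are said of these compounds alone.

Compound 1 `CCOC(=O)C1=C(N/N=C(\c2ccc([N+](=O)[O-])cc2)N2CCN(c3ccc(F)cc3)CC2)Nc2[nH]nc(C)c2C1c1ccc(N(C)C)cc1` sits at the limit > 100000 nM in a functional assay on MCF7 cells (Homo sapiens) for inhibition, read by MTT assay, with a stated time of 48 h; on this read-out lower numbers stand for stronger inhibition and higher numbers for weaker inhibition.
Compound 2 `CCOC(=O)C1=C(N/N=C(/C#N)C(=O)OCC)Nc2[nH]nc(C)c2C1c1ccc(N(C)C)cc1` gives 35600 nM in this assay.
Compound 3 `CCOC(=O)C1=C(NN=C(C#N)C#N)Nc2[nH]nc(C)c2C1c1ccc(N(C)C)cc1` gives 12100 nM in this assay.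

Among the two numbers shown, compound 3 stands lowest, with compound 2 nearest. For the measured compounds named here, the only measured step, a 2.9-fold lower number from compound 2 to compound 3 (0.47 log units; beyond the scatter), is modest and sits on the same amine nitrogen. Compound 1 reports only a limit, (the limit of > 100000 nM in this assay, at which 1 of the 3 values shown sits), and its group on that nitrogen carries aromatic rings.

Compound 4 `CCOC(=O)C1=C(N/C=N/c2ccc(C)cc2)Nc2[nH]nc(C)c2C1c1ccc(N(C)C)cc1` is not yet measured. It differs from compound 3 in one place: a group of 9 heavy atoms (8 carbon, 1 nitrogen; one six-membered aromatic ring of carbon only) in place of a group of 6 heavy atoms (3 carbon, 3 nitrogen; no ring), on an amine nitrogen. Going by the values given here, no measured step exchanges a ring-free group for one holding an aromatic ring at this nitrogen, so the step from compound 2 to compound 3 shows only that changes here move the number modestly. Compound 1, whose group at this site also holds aromatic rings, gives a limit, which points the other way.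

Compound 4 is therefore expected to give a higher number, a step of a 2.9-fold higher number from compound 3 to compound 4 (0.46 log units; beyond the scatter), with an estimate of 35000 nM and a range from 8000 nM to 150000 nM.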

Compound 4, half-maximal inhibitory concentration: 50500 nM
Compound 4: the middle estimate sits 1.4-fold (0.16 log units) below what was measured; low and high end bracket the measured number.
By their numbers in this assay, from the lowest: compound 3; then compounds 2 and 4 (each within the scatter of the next). At a limit, above all of these: compound 1.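

In this assay, for the compounds shown here, this is the first measured exchange on this amine nitrogen of a ring-free group for one holding a six-membered aromatic ring of carbon only, and the change is modest (a 4.2-fold higher number from compound 3 to compound 4 (0.62 log units; beyond the scatter)). The ring-free group of 9 heavy atoms and the ring-bearing group of 9 heavy atoms read alike, within the scatter (a 1.4-fold higher number from compound 2 to compound 4 (0.15 log units; within the scatter)), so among the measured values only the group of 6 heavy atoms stands apart. Compound 1, whose group on this nitrogen also holds aromatic rings, stands only at a limit: the limit of > 100000 nM in this assay, at which 1 of the 4 values shown sits.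

On these data alone, whether the number follows the size of the group or some other feature of it stays open with so few groups at this nitrogen. An acetyl or a plain methyl group here could show whether a still smaller group gives a lower number than the group of compound 3.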